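The source may hold more compounds than are shown below. What is called first, only, known or untested is meant among the compounds shown, and "the series" means these compounds.

Compound 1 `O=C(O)CC/C=C\C[C@H]1[C@H](F)CC[C@@H]1NS(=O)(=O)c1ccc(F)cc1` stands alone with a single number in a functional assay on a cell-free system (plasma) for inhibition of thromboxane A2 receptor (Homo sapiens), read by turbidimetry (on this read-out lower numbers stand for stronger inhibition and higher numbers for weaker inhibition), where compound 1 gives 750 nM. For the measured compounds named here, compound 2 `O=C(O)CCC/C=C\C[C@H]1[C@H](F)CC[C@@H]1NS(=O)(=O)c1ccc(F)cc1`, carrying a longer chain, gives in this assay 540 nM; 540 nM (2 entries) on each of two entries; no step between the two is worked out, and the values show only what they are. Compound 3 `O=C(O)CC/C=C\C[C@H]1[C@H](F)CC[C@@H]1NS(=O)(=O)c1ccccc1[N+](=O)[O-]` brings a single change from compound 1: 2-nitrophenyl in place of 4-fluorophenyl on a sulfonyl sulfur. Going by the values given here, no measured pair covers this change, so the expected step in this assay from compound 1 to compound 3 is a modest loss, possibly within the scatter, at a 2.0-fold higher number from compound 1 to compound 3 (0.30 log units; within the scatter). Compound 3 is therefore estimated at 1500 nM, ranging from 400 nM to 6000 nM.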

Compound 3, half-maximal inhibitory concentration: 560 nM
Compound 3: middle estimate off by 2.7-fold (0.43 log units), on the high side, within the range that was stated.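

In this assay, placing 2-nitrophenyl in place of 4-fluorophenyl on a sulfonyl sulfur gives a 1.3-fold lower number from compound 1 to compound 3 (0.13 log units; within the scatter), so this position accepts a group with more heavy atoms and with hydrogen-bond acceptors and the read-out stays within the scatter. This is the first step shown at this position, and it concerns only these two groups. No measurement shown offers a reason for this outcome. From the compounds shown here alone, it remains open whether 2-nitrophenyl would read the same on the longer chain of compound 2. Going by these compounds, how an unsubstituted phenyl or a naphthyl group on the sulfonyl sulfur would read also remains open.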